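A few compounds are considered here, and "the series" means these few. Any claim that something is new, unique, unknown or untested is made for them only; others in the source may bear on it.

Measured compounds:
compound 1 `Cc1ccccc1Nc1nc(NCc2ccccc2)ncc1Cl` gives > 100000 nM
compound 2 `CN1CCN(c2ccc(Nc3ncc(Cl)c(Nc4ccccc4)n3)nc2)CC1` gives > 100000 nM

In a functional assay on Jurkat cells (Homo sapiens) for inhibition, read by CCK-8 assay, with a stated time of 48 h (a lower number here means a stronger inhibitor of growth, a higher number a weaker inhibitor of growth), compound 1 reaches > 100000 nM, and this is a limit of the assay, not a number. In this assay compound 2 likewise reaches > 100000 nM, again a limit and not a number. So compound 2 stands at the edge of what this assay can report, and it is not alone there: the limit of > 100000 nM in this assay, at which 2 of the 2 values shown sit. Among the measured compounds shown here, neither measured compound gives a number that could anchor a step, and no pair of measured compounds differs in one place, so nothing here shows how a single change moves this assay.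

Compound 3 `COc1ccc(Nc2nc(Nc3ccc(N4CCN(C)CC4)cn3)ncc2Cl)cc1` differs from compound 2 in one place: methoxy in place of hydrogen on an aromatic carbon. With both measured values sitting at the limit, the step that the limit leaves unreadable from compound 2 to compound 3 is expected to be none beyond the scatter, in either direction. Compound 3 is therefore expected to stay at or near the limit, with an estimate of 150000 nM and a range from 30000 nM to 600000 nM, and most likely the assay will again report only a limit.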

Compound 3, concentration for 50% growth inhibition: 11200 nM
Beside the measured number, compound 3's estimate is 13-fold (1.13 log units) above it; the whole stated range lies above it.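

In this assay, methoxy in place of hydrogen on an aromatic carbon, para to a large group, brings an at least 8.9-fold lower number from compound 2 to compound 3 (0.95 log units; beyond the scatter), which shows that a change at this place on the anilino ring can move the read-out beyond the usual scatter. Among the compounds shown here, compound 3 gives 11200 nM, the only one of the three values shown that is an actual number, so the series now has a measured point from which later changes could be judged. The full size of this step still cannot be read, because it starts from a limit and not from a number: the limit of > 100000 nM in this assay, at which 2 of the 3 values shown sit.

The compounds shown leave open whether methoxy itself matters or whether a hydroxyl group, a fluorine atom or the longer ethoxy group on the same carbon would lower the number as far. They also leave open whether methoxy on another carbon of this ring would do the same, and how much further the number could fall from compound 3.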